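The source may report more compounds than this note shows. Statements on the series, on what has been measured and on what is new or still open speak of the compounds shown alone.

Compound 1 `O=C1O[C@H]([C@@H](O)Cn2cc(CNS(=O)(=O)c3ccc(Cl)cc3)nn2)C(OCc2ccccc2)=C1OCc1ccccc1` and compound 2 `Cc1ccc(-c2cn(C[C@H](O)[C@H]3OC(=O)C(OCc4ccccc4)=C3OCc3ccccc3)nn2)cc1` share one core and differ in a single group. In an ADME assay on HFF cells (Homo sapiens) for cytotoxicity, read by MTT assay, with a stated time of 72 h (on this read-out higher numbers stand for weaker inhibition and lower numbers for stronger inhibition), compound 1 gives 20 nM. Compound 2 sits at the limit of > 100000 nM in this assay, at which 1 of the 2 values shown sits, so its reading of > 100000 nM is a limit of the assay and not a number. That single change gave an at least 5000-fold higher number from compound 1 to compound 2 (3.69 log units; beyond the scatter). Compound 3 `Cc1ccc(S(=O)(=O)NCc2cn(C[C@H](O)[C@H]3OC(=O)C(OCc4ccccc4)=C3OCc3ccccc3)nn2)cc1` differs from compound 2 by (((4-methylphenyl)sulfonyl)amino)methyl in place of 4-methylphenyl on an aromatic carbon. This brings back the sulfonamide-bearing arm of compound 1, now with a methyl rather than a chlorine on the outer ring, so the step of an at least 2500-fold lower number from compound 2 to compound 3 (3.39 log units; beyond the scatter) is expected to be large, toward stronger inhibition. Compound 3 is estimated at 40 nM, between 10 nM and 400 nM.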

Compound 3, half-maximal inhibitory concentration: 50 nM
For compound 3 the middle estimate is 1.3-fold (0.10 log units) below the measured one, and the stated range covers the measured number.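

The (((4-methylphenyl)sulfonyl)amino)methyl group on this aromatic carbon gives an at least 2000-fold lower number from compound 2 to compound 3 (3.30 log units; beyond the scatter) in this assay, so the low reading does not depend on the chlorine of compound 1. Replacing that chloro with methyl has only a modest effect, with a 2.5-fold higher number from compound 1 to compound 3 (0.40 log units; beyond the scatter), which suggests that among these compounds the arm matters far more than this outer substituent. The reading for compound 2 is a limit and not a number: the limit of > 100000 nM in this assay, at which 1 of the 3 values shown sits.

As far as these compounds go, it remains open whether the sulfonyl group itself is needed, or whether an amide or a simple amine on the same methyl would read alike. From the compounds shown here alone, how a methoxy group or hydrogen on the outer ring would read also remains open.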